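Methoxy in place of fluoro: compound 3 to compound 4

A few compounds are considered here, and "the series" means these few. Any claim that something is new, unique, unknown or untested is made for them only; others in the source may bear on it.

Compound 3 `O=C(Nc1nc2ccc(F)cc2s1)c1cn(-c2ccccc2)nc1-c1ccc(Cl)cc1` gives 8860 nM in a functional assay on A549 cells (Homo sapiens) for cytotoxicity, read by MTT assay, with a stated time of 72 h (on this read-out lower numbers stand for stronger inhibition and higher numbers for weaker inhibition), and is the only one of the three measured compounds that returns a number rather than a limit. Compound 1 `COc1ccc2nc(NC(=O)c3cn(-c4ccccc4)nc3-c3ccccc3)sc2c1` sits at the limit of > 50000 nM in this assay. Compound 2 `COc1ccc2nc(NC(=O)c3cn(-c4ccccc4)nc3-c3ccc(F)cc3)sc2c1` likewise sits at the limit of > 50000 nM in this assay. Among the compounds with values here, the single measured step between neighbours, a step that the two limits leave unreadable from compound 1 to compound 2, stays unreadable, since both ends are limits (the limit of > 50000 nM in this assay, at which 2 of the 3 values shown sit).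

Compound 4 `COc1ccc2nc(NC(=O)c3cn(-c4ccccc4)nc3-c3ccc(Cl)cc3)sc2c1` differs from compound 3 by methoxy in place of fluoro on an aromatic carbon. Within the data shown here, no measured step covers this change, and no measured pair differs only here; the two methoxy compounds at the limit also carry other aryl groups, so their bearing is indirect. Compound 3 with its number is the nearest anchor, yet neither methoxy analogue reaches a number. In this assay the expected step is a 3.4-fold higher number from compound 3 to compound 4 (0.53 log units; beyond the scatter), a weakening, and a return of only a limit is judged about as likely as a number. The estimate for compound 4 is 30000 nM, with a range from 7000 nM to 120000 nM.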

Compound 4, half-maximal inhibitory concentration: 31400 nM
The estimate for compound 4 lay 1.0-fold (0.02 log units) below the measured number; measured number inside the range.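

In this assay, within the data shown here, compound 4 gives the series its only methoxy number, and this position proves sensitive to the swap of fluoro for methoxy on the six-membered aromatic ring: a 3.5-fold higher number from compound 3 to compound 4 (0.55 log units; beyond the scatter). On the methoxy compounds, the change to chloro gives an at least 1.5-fold lower number from compound 1 to compound 4 (0.20 log units; that floor lies within the scatter) and an at least 1.5-fold lower number from compound 2 to compound 4 (0.20 log units; that floor lies within the scatter), and both floors lie within the scatter, so no firm gain from chloro can be claimed. Compound 1 and compound 2 remain limits of the assay, not numbers: the limit of > 50000 nM in this assay, at which 2 of the 4 values shown sit.

As far as these compounds go, how an amine or a hydroxyl at this position would compare with fluoro and methoxy stays open. From the compounds shown here alone, the true distance of compound 1 and compound 2 from compound 4 also stays open, as does whether the step from compound 3 to compound 4 would hold with another aryl group on the shared core.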